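A few compounds are considered here, and "the series" means these few. Any claim that something is new, unique, unknown or untested is made for them only; others in the source may bear on it.

In a functional assay on the whole organism with Rattus norvegicus as the target, with a stated time of 4 h, at a dose of 40 mg/kg by the intraperitoneal route (on this read-out higher numbers stand for more inhibition at the one dose given (going by the name of the read-out) and lower numbers for less inhibition), three compounds have been measured so far. Compound 1 `Cc1nc2c(OCc3ccccc3)cccn2c1C(N)=O` gives 42%, compound 2 `Cc1nc2c(OCc3ccccc3)cccn2c1C#N` gives 25%, and compound 3 `Cc1nc2c(OCc3ccccc3)cccn2c1CO` gives 99%, the highest of the three, ahead of both others by steps beyond the scatter. Compound 4 `CCSCc1c(C)nc2c(OCc3ccccc3)cccn12` is not yet measured; it differs from compound 3 by ethylsulfanyl in place of hydroxy on a saturated chain carbon bound to an aromatic carbon. Among the measured compounds shown here, the steps that bear on this change are a number 57 percentage points higher from compound 1 to compound 3 (beyond the scatter) and a number 74 percentage points higher from compound 2 to compound 3 (beyond the scatter), both changes of the group on an aromatic carbon. They show the hydroxymethyl group far above carbamoyl and cyano, but neither tests ethylsulfanyl, so a drop is expected whose size is uncertain. The estimated step is a number 44 percentage points lower from compound 3 to compound 4 (beyond the scatter). For compound 4 the expected value is 55%, with a range from 20% to 95%.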

Compound 4, a percentage reported as inhibition, in the whole organism at one dose (the size of the read-out at that dose, not a potency): 36%
Beside the measured number, compound 4's estimate is 19 percentage points above it, within the range that was stated.
By their numbers in this assay, from the lowest: compound 2; then compounds 4 and 1 (each within the scatter of the next); then compound 3.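

In this assay, among the compounds shown here, ethylsulfanyl in place of hydroxy on the saturated chain carbon gives a number 63 percentage points lower from compound 3 to compound 4 (beyond the scatter), so the high number does not hold once hydroxy is replaced, which the earlier steps, all changes of the whole group on the aromatic carbon, could not show. The (ethylsulfanyl)methyl group in place of cyano gives a number 11 percentage points higher from compound 2 to compound 4 (beyond the scatter), and in place of carbamoyl it gives a number 6 percentage points lower from compound 1 to compound 4 (within the scatter), a step within the scatter. Nothing shown here accounts for these steps. From the compounds shown here alone, whether methoxy, an amine or a carboxylic acid on this chain carbon would keep the number stays open, as does whether the sulfur or the ethyl chain goes with the fall.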